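Bromo in place of trifluoromethyl: expectation for compound 3

A few compounds are considered here, and "the series" means these few. Any claim that something is new, unique, unknown or untested is made for them only; others in the source may bear on it.

Measured in a functional assay on MCF7 cells (Homo sapiens) for cytotoxicity, read by MTT assay, with a stated time of 4 days; a higher number here means a weaker inhibitor, a lower number a stronger inhibitor:
- compound 1 `C=C1C(=O)[C@]23C[C@@]1(O)CC[C@H]2c1ccc(O)c(C)c1[C@@H]3Cn1cc(-c2ccc(C(F)(F)F)cc2)nn1` gives 1840 nM.
- compound 2 `C=C1C[C@]23C[C@@]1(O)CC[C@@H]2c1cccc(C)c1[C@@H]3Cn1cc(-c2ccccn2)nn1` gives > 20000 nM, which is a limit of the assay and not a number.

For the measured compounds named here, compound 1 therefore stands as the only compound with a numerical value in this assay; the remaining value is the limit described by the limit of > 20000 nM in this assay, at which 1 of the 2 values shown sits. Going by the values given here, compound 1 and compound 2 differ in more than one place, so their two values show only that compound 1 is measurable where compound 2 is not, and no single change can be tied to that gap.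

Compound 3 `C=C1C(=O)[C@]23C[C@@]1(O)CC[C@H]2c1ccc(O)c(C)c1[C@@H]3Cn1cc(-c2ccc(Br)cc2)nn1` differs from compound 1 by bromo in place of trifluoromethyl on an aromatic carbon. Among the compounds with values here, no measured pair shares this change, so its size cannot be read from the data. The substituent that leaves and the one that enters are both single groups on the same aromatic carbon, and the step from compound 1 to compound 3 is expected to be small, a 1.1-fold higher number from compound 1 to compound 3 (0.04 log units; within the scatter), within the usual scatter rather than beyond it. Compound 3 is accordingly estimated at 2000 nM in this assay, with a range from 700 nM to 6000 nM.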

Compound 3, half-maximal inhibitory concentration: 270 nM
For compound 3 the middle estimate is 7.4-fold (0.87 log units) above the measured one; measured number below the stated range.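

In this assay, the change from 4-(trifluoromethyl)phenyl to 4-bromophenyl gives a 6.8-fold lower number from compound 1 to compound 3 (0.83 log units; beyond the scatter), so the choice of single group on this aromatic carbon, para to a large group, does register in the read-out of the core of compound 1. For the compounds shown here, this is the first step that can be read, as the earlier compounds differed in more than one place and offered no comparison tied to a single change. Nothing measured here accounts for the size of this step, which stands as an observation on these two groups alone.

On these data alone, two groups at this carbon give a single step and no trend, so it remains open whether chloro, methoxy, an amine or a carboxylic acid in the same place would fall near compound 3, near compound 1 or elsewhere. Also open, as far as these compounds go, is whether the same exchange of trifluoromethyl for bromo would shift the read-out by a similar amount on a core other than that of compound 1.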